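The source may report more compounds than this note shows. Statements on the series, on what has been measured and on what is new or still open speak of the compounds shown alone.

Working notes on the series: in a functional assay on A2780 cells (Homo sapiens) for antiproliferative activity, read by resazurin assay, with a stated time of 72 h (a higher number here means a weaker inhibitor, a lower number a stronger inhibitor), compound 1 `CN(Cc1ccccc1)C(=O)c1cc2c(Cc3ccccc3)n[nH]c2cc1O` gives 980 nM and is the only measured anchor so far. Compound 2 `Cc1ccccc1Cc1n[nH]c2cc(O)c(C(=O)N(C)Cc3ccccc3)cc12` carries no number, its entry reading "not determined" (no result reported) in this assay and so offering no baseline for the next step. The change to compound 3 `CN(Cc1ccccc1)C(=O)c1cc2c(Cc3cccc(Cl)c3)n[nH]c2cc1O` is 3-chlorophenyl in place of 2-methylphenyl on a saturated chain carbon bound to an aromatic carbon with 3-chlorophenyl in place of 2-methylphenyl on a saturated chain carbon bound to an aromatic carbon. Among the compounds with values here, no measured pair isolates this change, so its size in this assay cannot be read from the data. No step beyond the usual scatter is expected, and no direction is favoured, so the expectation rests on compound 1 at 980 nM as the sole reference point. The expected value for compound 3 is 900 nM with an estimated range from 300 nM to 2700 nM as the working window.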

Compound 3, half-maximal inhibitory concentration: 410 nM
For compound 3 the middle estimate is 2.2-fold (0.34 log units) above the measured one; low and high end bracket the measured number.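

In this assay, the place on a saturated chain carbon bound to an aromatic carbon accepts a substituent on its phenyl ring: chloro in place of hydrogen gives a 2.4-fold lower number from compound 1 to compound 3 (0.38 log units; beyond the scatter) and provides the first readable size for a change at this position. The comparison of 2-methylbenzyl with 3-chlorobenzyl cannot be read, as compound 2 has no number to set against compound 3. No available evidence accounts for the step.

A single substituted compound with a number leaves open whether the shift is specific to chloro or would also follow from another group on this ring. Going by these compounds, how a methoxy group, an amine or a carboxylic acid in the same place would read against compound 1 remains open.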